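Lengthening a Chain at the Assay Limit

This account rests on a few compounds, and the source may have more. Where it says the series, first, only, none or still open, it means among the compounds named here.

In a functional assay on HepG2 cells (Homo sapiens) for cytotoxicity, read by MTT assay, with a stated time of 72 h (on this read-out lower numbers stand for stronger inhibition and higher numbers for weaker inhibition), compound 1 `Cn1cccc1-c1nc2cc(NC(=O)CCCl)ccc2[nH]1` gives > 50000 nM, which is a limit of the assay and not a number. Compound 2 `Cc1ccc(-c2nc3cc(NC(=O)CN4CCN(C)CC4)ccc3[nH]2)cc1` gives > 50000 nM, which is also a limit. Compound 2 therefore offers no exact starting value, and it stands with compound 1 at the limit of > 50000 nM in this assay, at which 2 of the 2 values shown sit. Compound 3 `Cc1ccc(-c2nc3cc(NC(=O)CCN4CCN(C)CC4)ccc3[nH]2)cc1` carries (4-methylpiperazin-1-yl)methyl in place of 4-methylpiperazin-1-yl on a saturated chain carbon bound to a carbonyl carbon. In this assay, the expected step is a number no higher from compound 2 to compound 3 (the limit leaves the size open), which is estimated to stay within the usual scatter. The expected value for compound 3 is 50000 nM, with an estimated range of 15000 nM to 100000 nM.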

Compound 3, half-maximal inhibitory concentration: > 50000 nM
Compound 3 ended at the assay's limit; the forecaster's own chance of this, stated with the estimate: 70%; the middle value sits exactly at the limit.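

Going by these compounds alone, compound 2 and compound 3 both sit at the assay's limit, so no step between them can be read. The compounds shown leave open whether lengthening the chain changes activity at all in this assay.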